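A few compounds are considered here, and "the series" means these few. Any claim that something is new, unique, unknown or untested is made for them only; others in the source may bear on it.

Compound 2 (`COc1cc2nc([S+]([O-])CC(=O)Nc3ccccc3F)nc(Nc3c(Cl)cc(/C=C/C#N)cc3Cl)c2cc1OC`) gives > 208000 nM in an ADME assay on MT4 cells (Homo sapiens) for cytotoxicity, read by MTT assay, with a stated time of 5 days (a higher number here means that more compound is tolerated, a lower number that less compound is tolerated), and this is a limit and not a number. Compound 1 (`COc1cc2nc([S+]([O-])CC(=O)Nc3cccc(Cl)c3)nc(Nc3c(Cl)cc(/C=C/C#N)cc3Cl)c2cc1OC`), which carries 3-chlorophenyl, gives 68900 nM in this assay. Going by the values given here, the one measured step, with 2-fluorophenyl in place of 3-chlorophenyl on an amide-type nitrogen, is an at least 3.0-fold higher number from compound 1 to compound 2 (0.47 log units; beyond the scatter). Compound 3 (`COc1cc2nc([S+]([O-])CC(=O)Nc3cccc(C(F)(F)F)c3)nc(Nc3c(Cl)cc(/C=C/C#N)cc3Cl)c2cc1OC`) makes a further change, (3-(trifluoromethyl)phenyl in place of 2-fluorophenyl on an amide-type nitrogen), with 3-(trifluoromethyl)phenyl in place of 2-fluorophenyl on an amide-type nitrogen. The entering group resembles the 3-chlorophenyl of compound 1 more than it does 2-fluorophenyl, so that measured step, an at least 3.0-fold higher number from compound 1 to compound 2 (0.47 log units; beyond the scatter), is expected to run largely in reverse. The step expected in this assay is therefore an at least 2.9-fold lower number from compound 2 to compound 3 (0.47 log units; beyond the scatter), toward a lower number. For compound 3 the estimate is 70000 nM, with an expected range of 28000 nM to 180000 nM.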

Compound 3, half-maximal cytotoxic concentration: 21800 nM
For compound 3 the middle estimate is 3.2-fold (0.51 log units) above the measured one; measured number below the stated range.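

At this amide-type nitrogen the number in this assay also moves between two groups that look alike, since trifluoromethyl in place of chloro on an aromatic carbon gives a 3.2-fold lower number from compound 1 to compound 3 (0.50 log units; beyond the scatter). The change from 2-fluorophenyl to 3-(trifluoromethyl)phenyl gives an at least 9.5-fold lower number from compound 2 to compound 3 (0.97 log units; beyond the scatter), which leaves compound 3 as the least tolerated of the three. Compound 2 stands at a limit and not a number, so that step has a floor only: the limit of > 208000 nM in this assay, at which 1 of the 3 values shown sits.

Going by these compounds, whether the high tolerance of compound 2 follows the fluoro group or its place on the phenyl ring stays open, as 2-fluorophenyl differs from both 3-chlorophenyl and 3-(trifluoromethyl)phenyl in these two respects. On these data alone, how a plain phenyl, a 3-methoxyphenyl or a 3-aminophenyl would read in this assay is also open.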